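Thiophen-3-yl to 1-benzofuran-2-yl with dimethylamino retained

A few compounds are considered here, and "the series" means these few. Any claim that something is new, unique, unknown or untested is made for them only; others in the source may bear on it.

In a functional assay on HeLa S3 cells (Homo sapiens) for antiproliferative activity, read by XTT assay, with a stated time of 72 h (a higher number here means a weaker inhibitor, a lower number a stronger inhibitor), compound 3 `CN(C)c1ncnc2c1c(-c1ccsc1)cn2[C@@H]1O[C@H](CO)[C@@H](O)[C@H]1O` gives > 15000 nM, which is a limit of the assay and not a number. As far as these compounds go, its exact position on the scale therefore remains unknown. The step to compound 4 `CN(C)c1ncnc2c1c(-c1cc3ccccc3o1)cn2[C@@H]1O[C@H](CO)[C@@H](O)[C@H]1O` is 1-benzofuran-2-yl in place of thiophen-3-yl on an aromatic carbon, with the dimethylamino group unchanged.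

Two measured compounds already carry 1-benzofuran-2-yl. Compound 1 `COc1ncnc2c1c(-c1cc3ccccc3o1)cn2[C@@H]1O[C@H](CO)[C@@H](O)[C@H]1O` gives 9240 nM in this assay. Compound 2 `CNc1ncnc2c1c(-c1cc3ccccc3o1)cn2[C@@H]1O[C@H](CO)[C@@H](O)[C@H]1O` gives > 20000 nM, also a limit of the assay. For the measured compounds named here, the one measured step, an at least 2.1-fold higher number from compound 1 to compound 2 (0.33 log units; beyond the scatter), is methylamino in place of methoxy on an aromatic carbon and is beyond the scatter. It bears on this change only indirectly, since it does not exchange thiophen-3-yl for 1-benzofuran-2-yl. Going by the values given here, no measured pair isolates that exchange, so its size cannot be read directly from the data.

With compound 2 at > 20000 nM, compound 4 is expected to remain weak, and a further limit is quite possible. No step beyond the scatter is expected in this assay, in either direction. The expected step is a step that the limit leaves unreadable from compound 3 to compound 4. For compound 4 the estimated value is 16000 nM, with an expected range of 6000 nM to 30000 nM.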

Compound 4, half-maximal inhibitory concentration: > 20000 nM
Compound 4: a limit, no number; the forecaster's own chance of this, stated with the estimate: 60%; middle value at least 1.2-fold (0.09 log units) from the limit.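

In this assay, dimethylamino in place of methoxy with 1-benzofuran-2-yl retained gives an at least 2.1-fold higher number from compound 1 to compound 4 (0.33 log units; beyond the scatter). Together with an at least 2.1-fold higher number from compound 1 to compound 2 (0.33 log units; beyond the scatter), this means that both amines on this aromatic carbon, methylamino and dimethylamino, lie beyond the scatter from the methoxy compound when 1-benzofuran-2-yl is present, and compound 1 is the only one of the four compounds with a number rather than a limit. The steps to compound 4 from compound 3 and from compound 2 cannot be read, so neither the exchange of thiophen-3-yl for 1-benzofuran-2-yl nor the added methyl on the nitrogen has a size in this series: the limit of > 20000 nM in this assay, at which 2 of the 4 values shown sit.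

As far as these compounds go, whether thiophen-3-yl and 1-benzofuran-2-yl differ at all stays open, and a readable comparison would need both groups on a core that gives numbers rather than limits, such as the methoxy core of compound 1. An ethoxy group or an unsubstituted amino group on the same aromatic carbon, with 1-benzofuran-2-yl retained, would show whether the number for compound 1 is particular to methoxy or extends to other small groups there.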